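The source may report more compounds than this note shows. Statements on the series, on what has been measured and on what is new or still open speak of the compounds shown alone.

Measured so far:
Compound 1 `CCOC(=O)C(=O)Nc1cccc(N(C)C)c1C#N`: 0.2 mg/kg
Compound 2 `CCOC(=O)C(=O)Nc1cc(N(C)C)ccc1C#N`: 1.9 mg/kg

In a functional assay on the whole organism with Rattus norvegicus as the target (a higher number here means that more compound is needed for the effect, a lower number that less compound is needed), compound 1 gives 0.2 mg/kg, the lower of the two numbers. Compound 2 gives 1.9 mg/kg, and the gap between the two lies beyond the usual scatter. The next compound to be tested is compound 3 `CCOC(=O)C(=O)Nc1cccc(NC)c1C#N`. It differs from compound 1 in one place: hydrogen in place of methyl on a nitrogen on an aromatic ring. This puts hydrogen in place of methyl on a nitrogen on an aromatic ring, turning dimethylamino to methylamino. Within the data shown here, no measured pair here shows such a change on its own, so any forecast is rough. Compound 1, at 0.2 mg/kg, already holds the lower number, so a modest rise in this assay seems more likely than a further fall. The expected change is a 2.0-fold higher number from compound 1 to compound 3 (0.30 log units; within the scatter). For compound 3 the estimated value is 0.4 mg/kg, with an expected range from 0.1 mg/kg to 1.5 mg/kg.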

Compound 3, dose for half-maximal effect: 0.2 mg/kg
Compound 3: the middle estimate sits 2.0-fold (0.30 log units) above what was measured; the range from low to high includes it.
By their numbers in this assay, from the lowest: compounds 1 and 3 (each within the scatter of the next); then compound 2.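

In this assay, putting hydrogen in place of methyl on a nitrogen on an aromatic ring, which turns dimethylamino to methylamino, gives no change at the digits printed from compound 1 to compound 3 (within the scatter). Among these compounds, this is the first step here that isolates a single change, and it shows that, at this place and in this assay, one of the two methyl groups on the nitrogen can be exchanged for hydrogen without a change beyond the scatter. No measurement is available that bears on why the number holds.

The compounds shown leave open how a plain amino group, with no methyl left on that nitrogen, would behave. They also leave open whether an ethyl group or a longer chain on that nitrogen would be tolerated as well as methyl.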